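Fluorophenoxy for dichlorophenylsulfanyl on a diaminoquinoxaline

The source may hold more compounds than are shown below. What is called first, only, known or untested is meant among the compounds shown, and "the series" means these compounds.

Measured so far:
Compound 1, `Nc1cc(N)c2nc(-c3ccccc3)c(NCc3ccc(F)cc3)nc2c1`: 40700 nM
Compound 2, `COc1ccc(Sc2nc3cc(N)cc(N)c3nc2-c2ccccc2)cc1`: < 100000 nM
Compound 3, `Nc1cc(N)c2nc(-c3ccccc3)c(Sc3ccc(Cl)c(Cl)c3)nc2c1`: < 100000 nM

In a functional assay on NCI-H322M cells (Homo sapiens) for inhibition, read by sulforhodamine B assay, with a stated time of 48 h (a higher number here means that more compound is tolerated, a lower number that less compound is tolerated), compound 1 gives 40700 nM. For compound 2 this assay reports only a limit, < 100000 nM. For compound 3 likewise only a limit is known, < 100000 nM, so compound 3 cannot be placed as a number against compound 1; it stands at the limit of < 100000 nM in this assay, at which 2 of the 3 values shown sit, together with compound 2. The step that the limit leaves unreadable from compound 1 to compound 3 and the step that the two limits leave unreadable from compound 2 to compound 3 are therefore unreadable in size, as is a step that the limit leaves unreadable from compound 1 to compound 2.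

Compound 4, `Nc1cc(N)c2nc(-c3ccccc3)c(Oc3ccc(F)cc3)nc2c1`, has not yet been tested. It differs from compound 3 in one place: 4-fluorophenoxy in place of (3,4-dichlorophenyl)sulfanyl on an aromatic carbon. Going by the values given here, only compound 1 gives a number among the measured steps, and the two steps that lead to compound 3 are both hidden by the limit, so no measured step tells the size or direction of the change to compound 4. The expectation for compound 4 rests on compound 1 alone, whose value 40700 nM carries a group of similar shape on the same carbon; a step that the limit leaves unreadable from compound 3 to compound 4 of unreadable size is therefore expected. Compound 4 is estimated at 50000 nM in this assay, with a range from 15000 nM to 100000 nM.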

Compound 4, concentration lethal to 50% of the cells: 81300 nM
For compound 4 the middle estimate is 1.6-fold (0.21 log units) below the measured one; the measured number falls inside the stated range.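

In this assay, 4-fluorophenoxy in place of (4-fluorobenzyl)amino on the aromatic carbon next to the ring nitrogen is a 2.0-fold higher number from compound 1 to compound 4 (0.30 log units; within the scatter). Going by these compounds alone, this is the only readable step, and it shows that at this position the oxygen-linked 4-fluorophenyl group and the amino-linked 4-fluorobenzyl group cannot be told apart in this assay. All steps that involve compound 2 or compound 3 cannot be read, so the two arylsulfanyl groups remain unplaced against compound 1 and compound 4, and the exchange of (3,4-dichlorophenyl)sulfanyl for 4-fluorophenoxy has no measurable size; compound 2 and compound 3 are known only as limits: the limit of < 100000 nM in this assay, at which 2 of the 4 values shown sit.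

The compounds shown leave open whether any group on this carbon can move the number beyond the scatter, and whether the atom that links the aryl ring to the core matters at all. Nor do they show what a morpholine, a carboxylic acid or a longer alkyl chain on this carbon would do.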